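From compound 2 to compound 3: pyridin-3-yl for 2-methylphenyl

A few compounds are considered here, and "the series" means these few. Any claim that something is new, unique, unknown or untested is made for them only; others in the source may bear on it.

Compound 2 `CCCOc1ccc(C[C@@H](Cc2ccccc2)C(=O)O)cc1CNC(=O)c1ccc(-c2ccccc2C)cc1` gives < 1 ug/mL in a physicochemical assay for solubility, read by HPLC, in phosphate buffer, measured as thermodynamic solubility, with a stated time of 48 h, at pH 7.2 (a lower number here means a less soluble compound, a higher number a more soluble compound), and this is a limit of the assay, not a number. That places compound 2 at the limit of < 1 ug/mL in this assay, at which 1 of the 2 values shown sits. Going by the values given here, compound 1 `CCCOc1ccc(C[C@@H](Cc2ccccc2)C(=O)O)cc1CNC(=O)c1ccc(-c2cncnc2)cc1`, the only other measured member of the series, gives 190 ug/mL in this assay.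

Compound 3 `CCCOc1ccc(C[C@@H](Cc2ccccc2)C(=O)O)cc1CNC(=O)c1ccc(-c2cccnc2)cc1` carries pyridin-3-yl in place of the 2-methylphenyl of compound 2, on an aromatic carbon of a six-membered aromatic ring of carbon only, para to a large group: pyridin-3-yl in place of 2-methylphenyl on an aromatic carbon.

Among the compounds with values here, one measured step bears on this change: an at least 190-fold lower number from compound 1 to compound 2 (2.27 log units; beyond the scatter), with 2-methylphenyl in place of pyrimidin-5-yl at the same place. The new change runs the other way, away from 2-methylphenyl, but to a different group, and pyridin-3-yl has no measurement of its own in the series. The reference for the expectation is therefore compound 1 at 190 ug/mL, with some allowance for the difference between the two groups.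

A large step to a higher number is expected in this assay, estimated as an at least 50-fold higher number from compound 2 to compound 3 (1.69 log units; beyond the scatter). For compound 3 the estimated value is 50 ug/mL, with an expected range from 8 ug/mL to 200 ug/mL.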

Compound 3, solubility: 69.5 ug/mL
For compound 3 the middle estimate is 1.4-fold (0.14 log units) below the measured one, and the stated range covers the measured number.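

In this assay, the aromatic carbon para to a large group now carries a third group, and all three readings stand apart: pyridin-3-yl in place of 2-methylphenyl gives an at least 69-fold higher number from compound 2 to compound 3 (1.84 log units; beyond the scatter), while pyridin-3-yl in place of pyrimidin-5-yl gives a 2.7-fold lower number from compound 1 to compound 3 (0.44 log units; beyond the scatter). The large step seen earlier therefore does not depend on pyrimidin-5-yl itself: with pyridin-3-yl, whose ring holds 1 nitrogen, much of that step remains, and the gap left to pyrimidin-5-yl is modest, though beyond the scatter. The step from the 2-methylphenyl side has no upper bound, and compound 2 stands at a limit of the assay, not a number: the limit of < 1 ug/mL in this assay, at which 1 of the 3 values shown sits.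

Between 2-methylphenyl and pyridin-3-yl both the methyl and the ring nitrogen change at once, and the compounds shown cannot separate the two; a plain phenyl at this position would be the direct test. Also open is where an aminomethyl group or a morpholine on this same ring would fall in this assay relative to the three groups shown.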